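Thiazole-fused amidinohydrazones: methyl step from compound 2

The source may hold more compounds than are shown below. What is called first, only, known or untested is meant among the compounds shown, and "the series" means these compounds.

Measured compounds:
compound 1 `N=C(N)N/N=C/c1c(-c2cccs2)nc2n1CCS2`, 40700 nM
compound 2 `N=C(N)N/N=C/c1c(-c2ccsc2)nc2sccn12`, 31600 nM

Both compounds were run in a functional assay on cells (Cancer cell lines, Homo sapiens) for inhibition; on this read-out lower numbers stand for stronger inhibition of growth and higher numbers for weaker inhibition of growth. Compound 1 gives 40700 nM and compound 2 gives 31600 nM in this assay. The two numbers lie within the usual scatter of each other, so neither compound can be placed ahead of the other on what is known; compound 2 simply stands at one of two closely spaced values, with compound 1 as its only comparator.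

Compound 3 `Cc1cn2c(/C=N/NC(=N)N)c(-c3ccsc3)nc2s1` is the next compound and has not yet been measured in this assay. It differs from compound 2 by methyl in place of hydrogen on an aromatic carbon.

Within the data shown here, no pair of measured compounds differs in one place, so there is no measured step to lean on. A methyl entering for a hydrogen on an aromatic carbon is a small change, and the expectation is a step from compound 2 to compound 3 of a 1.1-fold lower number from compound 2 to compound 3 (0.02 log units; within the scatter), that is, none beyond the scatter in either direction. Compound 3 is therefore estimated at 30000 nM in this assay, with a range from 12000 nM to 75000 nM.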

Compound 3, concentration for total growth inhibition: 22400 nM
Compound 3: middle estimate off by 1.3-fold (0.13 log units), on the high side; the range from low to high includes it.
By their numbers in this assay, from the lowest: compounds 3, 2 and 1 (each within the scatter of the next).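

In this assay methyl in place of hydrogen on this aromatic carbon, next to the ring sulfur and two ring bonds from the ring nitrogen, gives a 1.4-fold lower number from compound 2 to compound 3 (0.15 log units; within the scatter) and so leaves the read-out where it was, as far as the scatter allows. Among these compounds, this is the first step that can be read at a single place, which the earlier pair could not offer: the position accepts one added carbon with no change that can be told from repeat measurement, though a single small group says little about the position as a whole. No measurement is at hand that would account for this step or tie it to any property of the methyl group.

Still open, from the compounds shown here alone, is whether a larger or different group on the same carbon, such as an ethyl, a longer chain, a phenyl ring, an amine or a carboxylic acid, would produce a step beyond the scatter in either direction. Also open is whether any change to the shared amidinohydrazone, the part common to all the compounds shown, would move the read-out more than this methyl does.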